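The source may hold more compounds than are shown below. What is called first, only, known or untested is meant among the compounds shown, and "the series" means these compounds.

Three compounds have so far been tested in a functional assay on L02 cells (Homo sapiens) for inhibition, read by MTT assay, with a stated time of 48 h; a higher number here means a weaker inhibitor, a lower number a stronger inhibitor:

compound 1 `COc1ccc(CNC(=O)/C=C/c2coc3cc(O)ccc3c2=O)cc1`: > 200000 nM, a limit of the assay rather than a number
compound 2 `COc1ccc2c(=O)c(/C=C/C(=O)Nc3cc(C)ccc3C)coc2c1`: > 200000 nM, also a limit
compound 3 `COc1ccc2c(=O)c(/C=C/C(=O)Nc3ccccc3OC)coc2c1`: > 200000 nM, also a limit

Compound 2 therefore stands only at a limit of this assay, and the two other values shown are limits as well. The step from compound 2 to compound 3, a step that the two limits leave unreadable from compound 2 to compound 3, cannot be read because both of its ends sit at the limit of > 200000 nM in this assay, at which 3 of the 3 values shown sit. The unmeasured compound 4 `COc1ccc2c(=O)c(/C=C/C(=O)Nc3ccccc3C)coc2c1` differs from compound 2 by hydrogen in place of methyl on an aromatic carbon, so that 2,5-dimethylphenyl becomes 2-methylphenyl. For the measured compounds named here, no measured step gives a readable size for such a change. With every value at the limit, compound 4 is expected to stay close to it, which means a step that the limit leaves unreadable from compound 2 to compound 4. The estimate for compound 4 is 400000 nM, within 150000 nM to 2000000 nM.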

Compound 4, half-maximal inhibitory concentration: > 200000 nM
Compound 4 gave a limit, no number; the forecaster's own chance of this, stated with the estimate: 85%; the middle value is on the limit's open side.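

The steps linking compound 4 with compound 2 and compound 3 cannot be read, because each end is a limit, not a number: the limit of > 200000 nM in this assay, at which 4 of the 4 values shown sit.

The compounds shown leave open how much any of these group changes alters inhibition in this assay.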